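Chloro for fluoro on the shared fused core

The source may hold more compounds than are shown below. What is called first, only, known or untested is meant among the compounds shown, and "the series" means these compounds.

Measured in an assay for inhibition of high affinity nerve growth factor receptor (Homo sapiens), read by HTRF, with a stated time of 30 min, in the presence of a further agent that is not named here; on this read-out lower numbers stand for stronger inhibition and higher numbers for weaker inhibition:
- compound 1, `Fc1ccc(CNc2nc(Nc3cc(C4CC4)[nH]n3)c3cc(F)ccc3n2)c(F)c1`, gives 59 nM
- compound 2, `Fc1ccc(CNc2nc(Nc3cc(C4CC4)[nH]n3)c3cc(Cl)ccc3n2)c(F)c1`, gives 72 nM
- compound 3, `Cc1cc(Nc2nc(NCc3ccc(F)cc3F)nc3cc(F)ccc23)n[nH]1`, gives 62 nM

Compound 1 and compound 2 differ in one place only: chloro in place of fluoro on an aromatic carbon. The step that this change made is a 1.2-fold higher number from compound 1 to compound 2 (0.09 log units; within the scatter), so the two numbers are not separated by more than the usual scatter.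

Compound 3 carries a different core from compound 1; the difference between the two cores is not broken down here. Its value in this assay sits between those of compound 1 and compound 2, all three within the scatter of one another, so no order among them can be drawn.

Compound 4, `Cc1cc(Nc2nc(NCc3ccc(F)cc3F)nc3cc(Cl)ccc23)n[nH]1`, has not yet been measured. It differs from compound 3 by chloro in place of fluoro on an aromatic carbon, which is the same change as that from compound 1 to compound 2, made at the same place on the core.

Because the measured pair gave a 1.2-fold higher number from compound 1 to compound 2 (0.09 log units; within the scatter), the step from compound 3 to compound 4 in this assay is expected to be of like size, a 1.2-fold higher number from compound 3 to compound 4 (0.06 log units; within the scatter). Compound 4 is accordingly estimated at 72 nM, with a likely range from 40 nM to 130 nM.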

Compound 4, half-maximal inhibitory concentration: 15 nM
Compound 4: middle estimate off by 4.8-fold (0.68 log units), on the high side; the measured number lies below the stated range.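

On the core of compound 3, chloro in place of fluoro on an aromatic carbon gives, in this assay, a 4.1-fold lower number from compound 3 to compound 4 (0.62 log units; beyond the scatter). The same change therefore does not carry over at one size from the core of compound 1 to the core of compound 3: the same change on two cores in this assay, a 1.2-fold higher number (0.09 log units; within the scatter) from compound 1 to compound 2 and a 4.1-fold lower number (0.62 log units; beyond the scatter) from compound 3 to compound 4, 5.0-fold (0.70 log units) apart, beyond the scatter of two such steps

This comparison rests on a single pair for each core; it shows that the core can alter the size of the step, but not which feature of the core does so, nor what the step would be on any further core.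

The compounds shown leave open whether other groups on the same aromatic carbon, such as bromo, methoxy or nitrile, would also separate the two cores. They also leave open whether an ethyl group or a longer chain in place of the methyl of compound 3 would keep the step seen on that core or bring it back within the scatter.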